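Lengthening a Chain in a Dopamine Transporter Series

The source may hold more compounds than are shown below. What is called first, only, known or untested is meant among the compounds shown, and "the series" means these compounds.

Measured so far:
compound 1, `CCOC(=O)Nc1cccc2c1CN(C)CC2c1ccccc1`: 2.5 mg/kg
compound 2, `CCCCOC(=O)Nc1cccc2c1CN(C)CC2c1ccccc1`: 12 mg/kg
compound 3, `CCNCC(=O)Nc1cccc2c1CN(C)CC2c1ccc(Cl)cc1`: about 25 mg/kg

In a functional assay on the whole organism for inhibition of sodium-dependent dopamine transporter (Mus musculus) (a higher number here means that more compound is needed for the effect, a lower number that less compound is needed), compound 1 gives the lowest number of the three. The change ethyl in place of hydrogen on a saturated chain carbon, two bonds along the chain from an oxygen next to a carbonyl group produced a 4.8-fold higher number from compound 1 to compound 2 (0.68 log units; beyond the scatter). Compound 3 has a different core and a different chain end; how its core differs from that of compound 1 is not broken down here. Compound 4, `CCCCNCC(=O)Nc1cccc2c1CN(C)CC2c1ccc(Cl)cc1`, is not yet measured and carries the change ethyl in place of hydrogen on a saturated chain carbon, two bonds along the chain from an amine nitrogen relative to compound 3. This is the same kind of change as from compound 1 to compound 2, though the place differs: there the chain sat two bonds along from an oxygen next to a carbonyl group, here two bonds along from an amine nitrogen. Because a 4.8-fold higher number from compound 1 to compound 2 (0.68 log units; beyond the scatter) was a modest rise, a similar but somewhat smaller rise is expected for compound 4, about a 2.8-fold higher number from compound 3 to compound 4 (0.45 log units; beyond the scatter), giving an estimated 70 mg/kg in this assay, likely between 30 mg/kg and 200 mg/kg.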

Compound 4, dose for half-maximal effect: 22 mg/kg
Beside the measured number, compound 4's estimate is 3.2-fold (0.50 log units) above it, and the stated range ends above it.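

In this assay, lengthening ethylamino to butylamino gave a 1.1-fold lower number from compound 3 to compound 4 (0.06 log units; within the scatter), so this change has no readable effect on this core. The same kind of change therefore does not carry over with the same size between the two cores: the same change on two cores in this assay, a 4.8-fold higher number (0.68 log units; beyond the scatter) from compound 1 to compound 2 and a 1.1-fold lower number (0.06 log units; within the scatter) from compound 3 to compound 4, 5.5-fold (0.74 log units) apart, beyond the scatter of two such steps. This warns against assuming that the step transfers within this series, but it does not show what sets the two steps apart, as the two pairs differ both in the core and in the chain end.

The compounds shown leave open whether the gap follows the core or the chain end. Also open, as far as these compounds go, is how a longer chain or a cyclic amine at the chain end would behave on the core of compound 3.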